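Trifluoromethoxy in place of trifluoromethyl on compound 2

The source may report more compounds than this note shows. Statements on the series, on what has been measured and on what is new or still open speak of the compounds shown alone.

In a physicochemical assay for solubility, read by HPLC, measured as kinetic solubility, with a stated time of 15 min (on this read-out higher numbers stand for higher solubility and lower numbers for lower solubility), compound 2 `O=[N+]([O-])c1cn2c(n1)OC[C@@H](OCC#Cc1ccc(-c3ccc(C(F)(F)F)cc3)cn1)C2` gives 0.33 ug/mL, the lower of the two actual numbers. Compound 3 `O=[N+]([O-])c1cn2c(n1)OC[C@H](OCC#Cc1ccc(-c3ccc(C(F)(F)F)cc3)cn1)C2` gives 0.68 ug/mL, and the two differ only as the fact that compounds 2 and 3 differ only in the configuration as drawn states. Compound 1 `O=[N+]([O-])c1cn2c(n1)OC[C@H](OCC#Cc1ccc(-c3ccc(OC(F)(F)F)cc3)cn1)C2` gives only a limit of the assay, < 0.1 ug/mL.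

Compound 4 `O=[N+]([O-])c1cn2c(n1)OC[C@@H](OCC#Cc1ccc(-c3ccc(OC(F)(F)F)cc3)cn1)C2` differs from compound 2 as follows: trifluoromethoxy in place of trifluoromethyl on an aromatic carbon. It carries trifluoromethoxy in place of trifluoromethyl on an aromatic carbon. The closest guide is the reverse exchange, an at least 6.8-fold higher number from compound 1 to compound 3 (0.83 log units; beyond the scatter), which is larger than a 2.1-fold higher number from compound 2 to compound 3 (0.31 log units; beyond the scatter). A clear drop beyond the scatter is therefore expected, and a limit may be all the assay reports.

The expected change is a 6.6-fold lower number from compound 2 to compound 4 (0.82 log units; beyond the scatter). Compound 4 is estimated at 0.05 ug/mL, with an expected range of 0.02 ug/mL to 0.2 ug/mL.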

Compound 4, solubility: 0.49 ug/mL
Compound 4: middle estimate off by 9.8-fold (0.99 log units), on the low side, and the stated range ends below it.
By their numbers in this assay, from the lowest: compounds 2, 4 and 3 (each within the scatter of the next, the first and the last beyond it). At a limit, below all of these: compound 1.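

In this assay, the exchange on this aromatic carbon gives a 1.5-fold higher number from compound 2 to compound 4 (0.17 log units; within the scatter), whereas the same two groups in the other configuration gave an at least 6.8-fold higher number from compound 1 to compound 3 (0.83 log units; beyond the scatter). The trifluoromethoxy pair also separates, with an at least 4.9-fold higher number from compound 1 to compound 4 (0.69 log units; beyond the scatter), on configuration alone: the fact that compounds 1 and 4 differ only in the configuration as drawn. The value of compound 1, < 0.1 ug/mL, is a limit of the assay and not a number.

Going by these compounds, how far this dependence on configuration extends to other groups at this place, such as an amine or a carboxylic acid, stays open. On these data alone, the true size of both steps from compound 1 also stays open.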